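The source may report more compounds than this note shows. Statements on the series, on what has been measured and on what is new or still open speak of the compounds shown alone.

Three compounds share one core and differ only at its edges. Compound 1 `CCC(=O)Nc1ccc(S(=O)(=O)Oc2ccccc2C(C)C)cc1` gives 7400 nM in a functional assay on HT-29 cells (Homo sapiens) for antiproliferative activity, read by sulforhodamine B assay, with a stated time of 48 h; on this read-out lower numbers stand for stronger inhibition and higher numbers for weaker inhibition. Compound 2 `CCC(=O)Nc1ccc(S(=O)(=O)Oc2ccccc2I)cc1` gives 11000 nM, and compound 3 `CCNC(=O)Nc1ccc(S(=O)(=O)Oc2ccccc2I)cc1` gives 5300 nM. Among these three numbers compound 1 stands second highest; the step of a 1.5-fold higher number from compound 1 to compound 2 (0.17 log units; within the scatter) lies within the scatter, as does its gap to compound 3, so no order can be read between these pairs. Among the compounds with values here, the one step that alters the group on the carbonyl carbon, a 2.1-fold lower number from compound 2 to compound 3 (0.32 log units; beyond the scatter), is modest but does lie beyond the scatter. Compound 4 `CC(C)c1ccccc1OS(=O)(=O)c1ccc(NC(=O)NC2CCCC2)cc1` differs from compound 1 at that same carbonyl carbon: cyclopentylamino in place of ethyl on a carbonyl carbon. Within the data shown here, only that single step bears on this change, and a cyclopentylamino group on the carbonyl carbon has not been measured, so the expectation rests on one observation. A modest lowering of the number is therefore expected, and the expected step is a 2.1-fold lower number from compound 1 to compound 4 (0.33 log units; beyond the scatter). Compound 4 is estimated at 3500 nM, within a range of 1500 nM to 8000 nM.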

Compound 4, half-maximal inhibitory concentration: 7400 nM
Beside the measured number, compound 4's estimate is 2.1-fold (0.33 log units) below it; the range from low to high includes it.
By their numbers in this assay, from the lowest: compounds 3, 1, 4 and 2 (each within the scatter of the next, the first and the last beyond it).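

In this assay the carbonyl carbon accepts a ring-bearing group without any visible effect: cyclopentylamino in place of ethyl gives no change at the digits printed from compound 1 to compound 4 (within the scatter) on the isopropyl-bearing core. The lowering seen with ethylamino in place of ethyl, a 2.1-fold lower number from compound 2 to compound 3 (0.32 log units; beyond the scatter) on the iodo-bearing core, therefore does not appear in this new pair, though the two steps differ both in the entering group and in the iodo or isopropyl group elsewhere on the core. No measurement at hand accounts for this result.

Still open, on these data alone, is whether ethylamino on the isopropyl-bearing core or cyclopentylamino on the iodo-bearing core would lower the number, which would separate the two differences. Also open, as far as these compounds go, is how a phenylamino group or a longer chain such as hexylamino on the carbonyl carbon would read.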